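This account rests on a few compounds, and the source may have more. Where it says the series, first, only, none or still open, it means among the compounds named here.

Of the compounds shown here, three of this set have been measured in a functional assay on LNCaP cells (Homo sapiens) for cytotoxicity, read by MTT assay, with a stated time of 48 h, in the absence of a further agent; on this read-out higher numbers stand for weaker inhibition and lower numbers for stronger inhibition. Compound 1 `COc1ccc2[nH]cc(-c3nc(C(=O)Nc4cc(OC)c(OC)c(OC)c4)cs3)c2c1` stops at the limit of the assay, giving > 100000 nM. Compound 2 `O=C(Nc1ccccc1)c1csc(-c2cn(Cc3ccc(Cl)cc3)c3ccccc23)n1` gives 64100 nM in this assay. Compound 3 `O=C(Nc1ccccc1)c1csc(-c2c[nH]c3ccccc23)n1` also stops at the limit, giving > 100000 nM. Among the compounds with values here, the one measured step between neighbours, an at least 1.5-fold higher number from compound 2 to compound 3 (0.19 log units; that floor lies within the scatter), runs into a limit and is therefore itself only a floor, since two of the three values sit at the limit of > 100000 nM in this assay, at which 2 of the 3 values shown sit. Compound 3 thus stands at a limit alone, without a number of its own.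

Compound 4 `O=C(NCc1ccccc1)c1csc(-c2c[nH]c3ccccc23)n1` differs from compound 3 in one place: benzyl in place of phenyl on an amide-type nitrogen. Within the data shown here, no measured step touches the amide-type nitrogen; the only known step changes a group on an aromatic nitrogen and yields only a floor. Nothing in the numbers therefore points to a step beyond the scatter, and compound 4 is expected to sit at the limit as well, an expected step of a number no higher from compound 3 to compound 4 (the limit leaves the size open). The estimate for compound 4 is 100000 nM, with a range from 40000 nM to 300000 nM.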

Compound 4, half-maximal inhibitory concentration: > 100000 nM
Compound 4: only a limit was reported; the forecaster's own chance of this, stated with the estimate: 70%; the middle value sits exactly at the limit.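

No step can be read from compound 3 to compound 4, since each gives only a limit and not a number: the limit of > 100000 nM in this assay, at which 3 of the 4 values shown sit. The compounds shown leave open whether benzyl in place of phenyl on the amide-type nitrogen changes the inhibition at all.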